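Cytotoxicity of Three Measured Compounds and One Analogue to Come

This account rests on a few compounds, and the source may have more. Where it says the series, first, only, none or still open, it means among the compounds named here.

compound 1 `Cc1nn(-c2ccccc2)c2nc(-c3ccccc3)c(C#N)c(-c3ccccc3O)c12`: > 23000 nM, a limit
compound 2 `CCc1ccc(-c2nc3c(c(C)nn3-c3ccccc3)c(-c3ccccc3C)c2C#N)cc1`: > 20000 nM, a limit
compound 3 `CCc1ccc(-c2nc3c(c(C)nn3-c3ccccc3)c(-c3ccccc3)c2C#N)cc1`: > 20000 nM, a limit

In an ADME assay on BJ cells (Homo sapiens) for cytotoxicity, with a stated time of 72 h (on this read-out lower numbers stand for an effect already at smaller amounts and higher numbers for an effect only at larger amounts of compound), compound 1 gives > 23000 nM, which is a limit of the assay rather than a number. Compound 2 gives > 20000 nM, also only a limit. Compound 3 gives > 20000 nM, again a limit. Compound 3 and compound 2 differ by methyl in place of hydrogen on an aromatic carbon, and the step that the two limits leave unreadable from compound 3 to compound 2.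

Compound 4 `Cc1ccc(-c2nc3c(c(C)nn3-c3ccccc3)c(-c3ccccc3O)c2C#N)cc1` is not yet measured. It differs from compound 1 by methyl in place of hydrogen on an aromatic carbon. This is the same kind of change as from compound 3 to compound 2, though the place differs: ortho to a large group there, para to a large group here. The difference between the cores of compound 1 and compound 3 is not broken down here.

Because the limit of > 20000 nM in this assay, at which 2 of the 3 values shown sit, and the limit of > 23000 nM in this assay, at which 1 of the 3 values shown sits, both sit at the limit, compound 4 is expected to show the step that the limit leaves unreadable from compound 1 to compound 4. Compound 4 is estimated at 25000 nM, most likely between 10000 nM and 70000 nM.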

Compound 4, half-maximal effective concentration: 22200 nM
For compound 4 the middle estimate is 1.1-fold (0.05 log units) above the measured one; the measured number falls inside the stated range.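

In this assay, putting a methyl on the aromatic carbon, which turns phenyl into 4-methylphenyl, gives an at least 1.0-fold lower number from compound 1 to compound 4 (0.01 log units; that floor lies within the scatter). From the compounds shown here alone, compound 1 stands at > 23000 nM, which is a limit and not a number, so the real size of this step stays unknown. The same kind of change on the other core, from compound 3 to compound 2, cannot be read either, so these data show neither that the change carries from one core to another nor that it fails to.

Going by these compounds, it remains open how a larger change at this place, such as an amine or a carboxylic acid in place of the methyl, would read in this assay. Also open, on these data alone, is at what amounts compound 1, compound 2 and compound 3 would show an effect.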